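Hydroxy for methyl on the piperidine amide of compound 3

A few compounds are considered here, and "the series" means these few. Any claim that something is new, unique, unknown or untested is made for them only; others in the source may bear on it.

Measured compounds:
Compound 1 `CC(C)(C)c1ccc(C(=O)N2CCC3(CC2)C(=O)N(CC(=O)N2CCN(S(C)(=O)=O)CC2)CN3c2ccccc2)cc1` gives 19000 nM in an assay on HEK293 cells for displacement of a labelled ligand from NPC1-like intracellular cholesterol transporter 1 (Homo sapiens); on this read-out higher numbers stand for weaker inhibition and lower numbers for stronger inhibition.
Compound 2 `CC(C)(C)c1ccc(C(=O)N2CCC3(CC2)C(=O)N(CC(=O)NCCN)CN3c2ccccc2)cc1` gives 7000 nM in this assay.
Compound 3 `CC1CCCN(C(=O)CN2CN(c3ccccc3)C3(CCN(C(=O)c4ccc(C(C)(C)C)cc4)CC3)C2=O)C1` gives 12000 nM in this assay.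

All three share one core and differ only in the group attached to the carbonyl carbon of the side chain. Compound 3 stands second highest of the three numbers; its gap to compound 1 is within the scatter, and its gap to compound 2 is likewise within the scatter. The step of a 1.6-fold lower number from compound 1 to compound 3 (0.20 log units; within the scatter) is within the scatter, whereas a 2.7-fold lower number from compound 1 to compound 2 (0.43 log units; beyond the scatter) is a modest step beyond it.

Compound 4 `CC(C)(C)c1ccc(C(=O)N2CCC3(CC2)C(=O)N(CC(=O)N2CCCC(O)C2)CN3c2ccccc2)cc1` differs from compound 3 by hydroxy in place of methyl on a saturated ring carbon. For the measured compounds named here, no measured step swaps one substituent for another on the same piperidine, so none bears directly on this change; the closest information is that the three different amide groups of compounds 1, 2 and 3 all stay in the same weak range. On that basis the step of no change at the digits printed from compound 3 to compound 4 (within the scatter) is expected to be small, with no clear direction beyond the scatter. Compound 4 is therefore estimated at 12000 nM in this assay, within a range of 5000 nM to 30000 nM.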

Compound 4, half-maximal inhibitory concentration: 12200 nM
Compound 4: the middle estimate sits 1.0-fold (0.01 log units) below what was measured, and the stated range covers the measured number.
By their numbers in this assay, from the lowest: compounds 2, 3, 4 and 1 (each within the scatter of the next, the first and the last beyond it).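

In this assay, for the compounds shown here, the swap of methyl for hydroxy at this ring carbon, two ring bonds from the ring nitrogen, gives (a 1.0-fold higher number from compound 3 to compound 4 (0.01 log units; within the scatter)), the first comparison in which the piperidine amide itself stays in place and only its substituent differs. Adding a hydrogen-bond donor and a hydrogen-bond acceptor here therefore produces no difference that can be told apart from the usual scatter. Compound 4 also cannot be separated from the two other amides, with (a 1.7-fold higher number from compound 2 to compound 4 (0.24 log units; within the scatter)) and (a 1.6-fold lower number from compound 1 to compound 4 (0.19 log units; within the scatter)), and no supporting measurement is available to account for any of these results.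

An amine, a carboxylic acid or a longer chain such as hydroxymethyl on this same ring carbon remains untested among the compounds shown, so it is open whether any group here could give a step beyond the scatter. From the compounds shown here alone, it is also open whether hydroxy or methyl on a different carbon of the piperidine would behave as these two do.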